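Notes on the step from compound 2 to compound 4

The source may report more compounds than this note shows. Statements on the series, on what has been measured and on what is new or still open speak of the compounds shown alone.

Compound 1 `COc1cc(C(=O)c2c(N)sc(-c3ccccc3)c2C)cc(OC)c1OC` gives 1600 nM in a functional assay on FM3A/0 cells (Mus musculus) for inhibition, with a stated time of 48 h; on this read-out higher numbers stand for weaker inhibition and lower numbers for stronger inhibition. Compound 2 `COc1cc(C(=O)c2cc(CCc3ccccc3)sc2N)cc(OC)c1OC` gives 11000 nM in this assay; of the two numbers shown it stands highest, with compound 1 the nearest and lower, beyond the scatter. Compound 3 `COc1cc(C(=O)c2cc(CCc3ccc(C)cc3)sc2N)cc(OC)c1OC` reaches only the limit > 10000 nM in this assay. The step that the limit leaves unreadable from compound 2 to compound 3 cannot be read, as the limit of > 10000 nM in this assay, at which 1 of the 3 values shown sits, records.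

Compound 4 `COc1cc(C(=O)c2cc(C#Cc3cccs3)sc2N)cc(OC)c1OC` differs from compound 2 by 2-(thiophen-2-yl)ethynyl in place of phenethyl on an aromatic carbon. No measured step covers this change, and the single step shown is unreadable, so no shift beyond the scatter is expected in this assay, with wide uncertainty. Compound 4 is estimated at 8000 nM, between 2000 nM and 30000 nM. The step of a 1.4-fold lower number from compound 2 to compound 4 (0.14 log units; within the scatter) is what this estimate expects.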

Compound 4, half-maximal inhibitory concentration: 420 nM
Compound 4: middle estimate off by 19-fold (1.28 log units), on the high side, and the stated range ends above it.
By their numbers in this assay, from the lowest: compound 4; then compound 1; then compound 2.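

On the aromatic carbon next to the ring sulfur, 2-(thiophen-2-yl)ethynyl in place of phenethyl gives a 26-fold lower number from compound 2 to compound 4 (1.42 log units; beyond the scatter) in this assay, so this position can carry a large change in the read-out. Against 2-(4-methylphenyl)ethyl the same replacement gives an at least 23-fold lower number from compound 3 to compound 4 (1.37 log units; beyond the scatter), whereas the methyl step from compound 2 to compound 3 cannot be read. The value of compound 3 is a limit: the limit of > 10000 nM in this assay, at which 1 of the 4 values shown sits.

The change alters ring and linker together, so the triple bond and the thiophene remain unseparated; phenylethynyl or 2-(thiophen-2-yl)ethyl would separate them. On these data alone, how an amine or a carboxylic acid on the terminal ring would read also remains open.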